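Halogen swap on the pendant phenyl: outlook for compound 3

This account rests on a few compounds, and the source may have more. Where it says the series, first, only, none or still open, it means among the compounds named here.

In a functional assay on SMMC-7721 cells (Homo sapiens) for cytotoxicity, read by MTT assay, with a stated time of 72 h (a higher number here means a weaker inhibitor, a lower number a stronger inhibitor), compound 2 `COc1cc2c(Oc3ccc(NC(=O)c4cc(-c5ccc(F)cc5)nc5ccccc45)cc3F)ccnc2cc1OCCCN1CCCCC1` gives 74 nM, the lowest of the two numbers in hand; compound 1 `COc1cccc(-c2cc(C(=O)Nc3ccc(Oc4ccnc5cc(OCCCN6CCCCC6)c(OC)cc45)c(F)c3)c3ccccc3n2)c1` gives 380 nM. Among the measured compounds shown here, the one step available is a 5.1-fold lower number from compound 1 to compound 2 (0.71 log units; beyond the scatter), and it changed this same pendant ring. Compound 3 `COc1cc2c(Oc3ccc(NC(=O)c4cc(-c5cccc(Cl)c5)nc5ccccc45)cc3F)ccnc2cc1OCCCN1CCCCC1` carries 3-chlorophenyl in place of 4-fluorophenyl on an aromatic carbon. For the measured compounds named here, no measured step exchanges one halogenated phenyl for another, so the earlier step only bounds how far an aryl change can move this assay. A step within or just beyond the scatter is expected, toward a slightly higher number; the estimated step is a 1.6-fold higher number from compound 2 to compound 3 (0.21 log units; within the scatter). For compound 3 the estimate is 120 nM, range 40 nM to 400 nM.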

Compound 3, half-maximal inhibitory concentration: 30 nM
The estimate for compound 3 lay 4.0-fold (0.60 log units) above the measured number, and the stated range ends above it.
By their numbers in this assay, from the lowest: compound 3; then compound 2; then compound 1.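

At this aromatic carbon next to the ring nitrogen, exchanging one halogenated phenyl for another still shifts this assay (a 2.5-fold lower number from compound 2 to compound 3 (0.39 log units; beyond the scatter)). 3-Chlorophenyl in place of 3-methoxyphenyl has a large effect in the same assay (a 13-fold lower number from compound 1 to compound 3 (1.10 log units; beyond the scatter)), so the choice of group at a shared ring position matters here. No measurement bears on the cause of either step.

Compound 2 and compound 3 differ in both halogen and ring position, so these two contributions stay unseparated. Going by these compounds, how an amine or a carboxylic acid on the pendant phenyl would read in this assay also remains open.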